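Replacing the imidazopyridine arm of compound 3 with a dimethyltriazole

The source may report more compounds than this note shows. Statements on the series, on what has been measured and on what is new or still open speak of the compounds shown alone.

Measured compounds:
- Compound 1 `C[C@@H]1CN(c2sc(C(F)(F)F)nc2-c2nc3ccccc3[nH]2)CCN1C(=O)Cn1cnc2cccnc21` gives 31 nM in a functional assay on U2OS cells for antagonist activity at C-X-C chemokine receptor type 3 (Homo sapiens), read by beta-arrestin recruitment; a higher number here means a weaker inhibitor, a lower number a stronger inhibitor.
- Compound 2 `CCOc1ncc(-c2nc(C(F)(F)F)sc2N2CCN(C(=O)Cn3cnc4cccnc43)[C@H](C)C2)cn1` gives 20 nM in this assay.
- Compound 3 `CCCc1ncc(-c2nc(C(F)(F)F)sc2N2CCN(C(=O)Cn3cnc4cccnc43)[C@H](C)C2)cn1` gives 33 nM in this assay.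

Compound 3 sits at the upper end of these three numbers, yet both steps leading to it, a 1.1-fold higher number from compound 1 to compound 3 (0.03 log units; within the scatter) and a 1.7-fold higher number from compound 2 to compound 3 (0.22 log units; within the scatter), stay within the scatter, so the three compounds are effectively indistinguishable in this assay.

Compound 4 `CCCc1ncc(-c2nc(C(F)(F)F)sc2N2CCN(C(=O)Cn3nc(C)nc3C)[C@H](C)C2)cn1` differs from compound 3 in one place: a group of 7 heavy atoms (4 carbon, 3 nitrogen; one five-membered aromatic ring with 3 hetero atoms) in place of a group of 9 heavy atoms (6 carbon, 3 nitrogen; one five-membered aromatic ring with 2 hetero atoms, one six-membered aromatic ring with 1 hetero atom), on a saturated chain carbon bound to a carbonyl carbon. All three measured steps, a 1.6-fold lower number from compound 1 to compound 2 (0.19 log units; within the scatter), a 1.1-fold higher number from compound 1 to compound 3 (0.03 log units; within the scatter) and a 1.7-fold higher number from compound 2 to compound 3 (0.22 log units; within the scatter), alter the aromatic group attached to the shared core and leave the amide side chain untouched. None of them bears on the change from compound 3 to compound 4, so there is no measured guidance for it. The side chain has never been varied in this assay. The expectation must therefore be wide. Compound 4 is expected to be a somewhat weaker inhibitor, with the step of a 2.1-fold higher number from compound 3 to compound 4 (0.33 log units; beyond the scatter) taken as the best guess. Compound 4 is estimated at 70 nM, within a range from 15 nM to 350 nM.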

Compound 4, half-maximal inhibitory concentration: 258 nM
Beside the measured number, compound 4's estimate is 3.7-fold (0.57 log units) below it; measured number inside the range.
By their numbers in this assay, from the lowest: compounds 2, 1 and 3 (each within the scatter of the next); then compound 4.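

This is the first change shown to the arm on the saturated chain carbon bound to a carbonyl carbon, and it gives a clear shift in this assay (a 7.8-fold higher number from compound 3 to compound 4 (0.89 log units; beyond the scatter)), whereas the earlier steps, all made at the aromatic group on the shared core, stayed within the scatter. The arm therefore matters for inhibition in this series: going from the two-ring group of compound 3 to the smaller one-ring 3,5-dimethyl-1H-1,2,4-triazol-1-yl weakens the compound, even though the counts of hydrogen-bond donors and acceptors stay the same, so those counts alone do not decide the outcome at this position. Nothing measured here gives a reason for this loss.

The compounds shown cannot separate the effect of losing the six-membered ring from the effect of the two methyl groups on the new ring, a question that an unsubstituted 1,2,4-triazol-1-yl or a plain imidazol-1-yl on the same chain carbon could address. From the compounds shown here alone, it also remains open whether the same swap would weaken compound 1 or compound 2 to a similar extent.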